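The source may hold more compounds than are shown below. What is called first, only, known or untested is meant among the compounds shown, and "the series" means these compounds.

Compound 1 `Cc1ccc2[nH]c(C(=O)N[C@H]3CN(S(=O)(=O)c4ccccc4)C[C@@H]3C(=O)NC[C@H]3CCCN3)cc2c1` is the starting point of the pair measured so far: in a functional assay on HEK293 cells for agonist activity at growth hormone secretagogue receptor type 1 (Homo sapiens), read by HTRF and inositol phosphate accumulation, with a stated time of 90 min, in the presence of a further agent that is not named here (a lower number here means a smaller maximal response, a higher number a larger maximal response), compound 1 gives 94%. Compound 2 `Cc1ccc2[nH]c(C(=O)N[C@H]3CN(S(=O)(=O)c4ccccc4)C[C@@H]3C(=O)NC[C@@H]3CCCN3C)cc2c1` carries 1-methylpyrrolidin-2-yl in place of pyrrolidin-2-yl on a saturated chain carbon bound to an amide-type nitrogen, and in this assay compound 2 gives 87%. The measured step is a number 7 percentage points lower from compound 1 to compound 2 (within the scatter). On the numbers shown, compound 2 has the lowest of the two values, and its nearest neighbour is compound 1, whose value is higher by an amount that lies within the scatter, so the two compounds cannot be ordered.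

Compound 3 `Cc1ccc2[nH]c(C(=O)N[C@H]3CN(S(=O)(=O)c4ccccc4)C[C@@H]3C(=O)NC[C@H]3CCCN3C)cc2c1` is the compound not yet measured. How it differs from compound 2: the two compounds have the same atoms and bonds and differ only in configuration as drawn: 1 of 3 stereo elements differ; a stereocentre at a saturated ring carbon is drawn S in compound 2 and R in compound 3. Going by the values given here, no measured step concerns a change of configuration; the only step at hand, a number 7 percentage points lower from compound 1 to compound 2 (within the scatter), concerns a different change and was within the scatter, so it gives no direction for this one. Compound 3 is therefore expected to show no step beyond the scatter, with a number 5 percentage points lower from compound 2 to compound 3 (within the scatter) as the expected change. The estimate for compound 3 in this assay is 82%, with a range from 55% to 100%.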

Compound 3, largest response reached (Emax), in percent of the reference or control that the assay uses in the growth hormone secretagogue receptor type 1 assay: 98%
Estimate against measurement, compound 3: 16 percentage points below, within the range that was stated.
By their numbers in the growth hormone secretagogue receptor type 1 assay, from the lowest: compounds 2, 1 and 3 (each within the scatter of the next, the first and the last beyond it).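

Going by these compounds alone, in the growth hormone secretagogue receptor type 1 assay, the configuration at the saturated ring carbon is the first change to give a step beyond the scatter, although a modest one: a number 11 percentage points higher from compound 2 to compound 3 (beyond the scatter), and this step can be assigned to that stereocentre alone because of the following: the fact that compounds 2 and 3 differ only in the configuration as drawn. The change leaves lipophilicity unmoved, as in a physicochemical assay for lipophilicity, measured as octanol-water partition, at pH 7.4 (a higher number here means a more lipophilic compound, a lower number a more polar compound), compound 2 gives 2.3 and compound 3 gives 2.3, with no change at the digits printed from compound 2 to compound 3 (within the scatter). Back in the growth hormone secretagogue receptor type 1 assay, the comparison of the secondary amine with its methylated partner gives a number 4 percentage points higher from compound 1 to compound 3 (within the scatter), so methyl in place of hydrogen on the ring amine nitrogen brings no distinguishable change in maximal response when the ring carbon is drawn as in compound 3.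

The compounds shown leave open whether the effect of configuration holds with a larger substituent on the ring nitrogen, such as ethyl or benzyl, or with a piperidin-2-yl group in place of the pyrrolidine. They also leave open how the two configurations compare in potency, since maximal response alone says nothing about the concentration needed to reach it.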